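One Added Methyl on the Carboxymethyl Chain

The source may report more compounds than this note shows. Statements on the series, on what has been measured and on what is new or still open speak of the compounds shown alone.

In an ADME assay on the whole organism (Mus musculus, strain CD1) for pharmacokinetics, read by LC-MS, with a stated time of 24 h, at a dose of 1 mg/kg by the intravenous route (a higher number here means that more of the compound sits outside the plasma, a lower number that more of the compound stays in the plasma), compound 1 (`O=C(O)Cn1nc(Cc2nc3cc(Cl)c(OCC(F)F)cc3[nH]2)c2ccccc2c1=O`) gives 1.2 L/kg and compound 2 (`O=C(O)Cn1nc(Cn2cc3cc(OCC4CC4)c(Cl)cc3n2)c2ccccc2c1=O`) gives 0.69 L/kg, two values within the scatter of each other. Compound 3 (`C[C@H](C(=O)O)n1nc(Cn2cc3cc(OCC4CC4)c(Cl)cc3n2)c2ccccc2c1=O`) differs from compound 2 by methyl in place of hydrogen on a saturated chain carbon bound to an aromatic nitrogen and a carbonyl carbon. Among the compounds with values here, no measured pair shows this change, so nothing beyond the scatter is expected in this assay. The expected step is small, a 1.1-fold lower number from compound 2 to compound 3 (0.03 log units; within the scatter). For compound 3 the estimate is 0.65 L/kg, with an expected range of 0.33 L/kg to 1.3 L/kg.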

Compound 3, volume of distribution at steady state in the Mus musculus assay: 1.9 L/kg
Compound 3: middle estimate off by 2.9-fold (0.47 log units), on the low side; measured number above the stated range.
By their numbers in the Mus musculus assay, from the lowest: compounds 2, 1 and 3 (each within the scatter of the next, the first and the last beyond it).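

Carboxymethyl to 1-carboxyethyl gives the first reading of a change at this saturated chain carbon, and in the Mus musculus assay the added methyl gives a 2.8-fold higher number from compound 2 to compound 3 (0.44 log units; beyond the scatter). In a physicochemical assay for lipophilicity, at pH 7.4 (on this read-out higher numbers stand for higher lipophilicity and lower numbers for lower lipophilicity), compound 2 gives 2.79 and compound 3 gives 2.99. In the physicochemical assay the same change gives a number 0.20 log units higher from compound 2 to compound 3 (within the scatter). The two read-outs do not move alike in this one pair. No evidence on the cause of the step is at hand.

On these data alone, an ethyl group or a longer chain on this carbon remains open, as does the mirror-image form of compound 3. So does the same methyl on the core of compound 1.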